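This account rests on a few compounds, and the source may have more. Where it says the series, first, only, none or still open, it means among the compounds named here.

Measured in a functional assay on HL-60 cells (Homo sapiens) for antiproliferative activity, read by XTT assay, with a stated time of 72 h; on this read-out lower numbers stand for stronger inhibition and higher numbers for weaker inhibition:

- Compound 1 `CSc1ncnc2c1c(-c1cccs1)cn2[C@@H]1O[C@H](CO)[C@@H](O)[C@H]1O`: 1130 nM
- Compound 2 `CNc1ncnc2c1c(-c1ccco1)cn2[C@@H]1O[C@H](CO)[C@@H](O)[C@H]1O`: 620 nM
- Compound 3 `CNc1ncnc2c1c(-c1ccoc1)cn2[C@@H]1O[C@H](CO)[C@@H](O)[C@H]1O`: > 15000 nM

Compound 3 stands at the top of this short series, and what it gives is not a number. Its reading of > 15000 nM is a limit of the assay.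

The next compound, compound 4 `CNc1ncnc2c1c(-c1cccs1)cn2[C@@H]1O[C@H](CO)[C@@H](O)[C@H]1O`, has yet to be measured in this assay. It carries thiophen-2-yl in place of furan-3-yl on an aromatic carbon.

Going by the values given here, one measured step bears directly on this change. Placing furan-3-yl where furan-2-yl stood gave an at least 24-fold higher number from compound 2 to compound 3 (1.38 log units; beyond the scatter), a large loss that ended at the limit. Compound 4 leaves the furan-3-yl behind and takes a group joined through its 2-yl carbon, as in compound 2, which gives 620 nM. Compound 1 already bears thiophen-2-yl, although its core differs in one other place, and it gives 1130 nM. Both of these readings suggest that compound 4 should return to the same region.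

A large change towards stronger inhibition is therefore expected, with the estimated move being an at least 21-fold lower number from compound 3 to compound 4 (1.33 log units; beyond the scatter). Compound 4 is estimated at 700 nM, with an expected range from 200 nM to 3000 nM.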

Compound 4, half-maximal inhibitory concentration: > 20000 nM
Compound 4: a limit, no number; the forecaster's own chance of this, stated with the estimate: 8%; middle value at least 28-fold (1.45 log units) from the limit.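

In this assay compound 4 gives a limit and not a number: the limit of > 20000 nM in this assay, at which 1 of the 4 values shown sits. Compound 3 also stands at a limit, so the step between these two compounds cannot be read and the two cannot be ranked, but the result does show that a group joined through its 2-yl carbon is not enough at this position: thiophen-2-yl in place of furan-2-yl gives an at least 32-fold higher number from compound 2 to compound 4 (1.50 log units; beyond the scatter), a large loss of the same kind that furan-3-yl brought, and among these methylamino compounds only compound 2 gives a number. The group on the other aromatic carbon also counts with thiophen-2-yl kept, since methylamino in place of methylsulfanyl gives an at least 17-fold higher number from compound 1 to compound 4 (1.24 log units; beyond the scatter), so thiophen-2-yl keeps a measurable reading only in the core of compound 1.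

The compounds shown leave open whether furan-2-yl would hold its reading with methylsulfanyl on the core, and how far compound 3 and compound 4 actually lie beyond their limits. They also leave open whether a phenyl or a thiophen-3-yl ring at this position, or a plain amino group in place of methylamino, would give a measurable reading.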